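A few compounds are considered here, and "the series" means these few. Any claim that something is new, unique, unknown or untested is made for them only; others in the source may bear on it.

Measured so far in a functional assay on K562 cells (Homo sapiens) for cytotoxicity, in the presence of a further agent that is not named here; on this read-out higher numbers stand for weaker inhibition and lower numbers for stronger inhibition: compound 1 `Cc1ccc(-c2cc(-c3ccc(Cl)o3)cc(-c3ccsc3)n2)o1` gives 23300 nM; compound 2 `Clc1ccc(-c2cc(-c3ccoc3)cc(-c3ccsc3)n2)cc1` gives 730 nM; compound 3 `Clc1ccc(-c2cc(-c3ccsc3)nc(-c3ccccn3)c2)o1` gives 21900 nM.

Compound 3 stands second highest of these three numbers; compound 1 sits close to it, while compound 2 gives a far lower number. Compound 4 `Clc1ccc(-c2cc(-c3ccc(Cl)o3)cc(-c3ccsc3)n2)cc1` is the next step: 4-chlorophenyl in place of pyridin-2-yl on an aromatic carbon. Within the data shown here, the only measured step that swaps one group on an aromatic carbon of the shared core, a 1.1-fold lower number from compound 1 to compound 3 (0.03 log units; within the scatter), stayed within the scatter, so on that evidence alone no change beyond the scatter would be expected. Yet compound 2, which also carries a 4-chlorophenyl, gives the lowest number in this assay. Weighing both, the step of a 5.5-fold lower number from compound 3 to compound 4 (0.74 log units; beyond the scatter) is expected to be a moderate fall. Compound 4 is therefore estimated at 4000 nM, within 800 nM to 20000 nM.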

Compound 4, half-maximal inhibitory concentration: 18700 nM
Compound 4: the middle estimate sits 4.7-fold (0.67 log units) below what was measured, within the range that was stated.
By their numbers in this assay, from the lowest: compound 2; then compounds 4, 3 and 1 (each within the scatter of the next).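

With the 5-chlorofuran-2-yl and thiophen-3-yl groups kept in place, 4-chlorophenyl and pyridin-2-yl cannot be told apart at this position (a 1.2-fold lower number from compound 3 to compound 4 (0.07 log units; within the scatter)). The same holds for 4-chlorophenyl and 5-methylfuran-2-yl (a 1.2-fold lower number from compound 1 to compound 4 (0.10 log units; within the scatter)), so all three groups here give matching numbers. The large change comes from the other place, where 5-chlorofuran-2-yl stands in place of furan-3-yl (a 26-fold higher number from compound 2 to compound 4 (1.41 log units; beyond the scatter)).

No measurement shown explains why this position stays flat. On these data alone, whether an amine or a carboxylic acid on this carbon would move the number remains open, as does whether these groups would still match alongside furan-3-yl.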